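A tolyl sulfonamide on a benzoxazole core: expected cytotoxicity

A few compounds are considered here, and "the series" means these few. Any claim that something is new, unique, unknown or untested is made for them only; others in the source may bear on it.

Measured compounds:
compound 1, `O=S(=O)(Nc1ccc2oc(-c3ccccc3)nc2c1)c1ccc(Cl)c(Cl)c1`, 71000 nM
compound 2, `O=S(=O)(Nc1ccc2oc(-c3ccccc3)nc2c1)c1ccc(Cl)c(C(F)(F)F)c1`, 66000 nM
compound 3, `O=S(=O)(Nc1ccc(-c2nc3ccccc3o2)cc1)c1ccc(Cl)c(C(F)(F)F)c1`, 69000 nM

All three numbers come from an ADME assay on HEK293 cells (Homo sapiens) for cytotoxicity, read by resazurin assay, with a stated time of 48 h; on this read-out lower numbers stand for higher toxicity in this test and higher numbers for lower toxicity in this test. For the measured compounds named here, compound 1 stands alongside the other two: the move from compound 1 to compound 2 is a 1.1-fold lower number from compound 1 to compound 2 (0.03 log units; within the scatter), and the gap between compound 1 and compound 3 is likewise within the scatter, so no compound can be set apart from the others on these data.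

Compound 4, `Cc1ccc(S(=O)(=O)Nc2ccc3oc(-c4ccccc4)nc3c2)cc1`, has not yet been measured. It differs from compound 1 at one place: 4-methylphenyl in place of 3,4-dichlorophenyl on a sulfonyl sulfur. Going by the values given here, the only measured step on the same ring, from compound 1 to compound 2, exchanged one substituent for another and gave a 1.1-fold lower number from compound 1 to compound 2 (0.03 log units; within the scatter), a change that is within the scatter. Among the compounds with values here, that step bears on the present change only loosely, since here the whole 3,4-dichlorophenyl leaves and 4-methylphenyl enters; no measured pair covers such an exchange. With three compounds of different substitution all sitting at nearly the same number, the expectation for compound 4 is a step of about a 1.1-fold higher number from compound 1 to compound 4 (0.02 log units; within the scatter), that is, no change beyond the scatter in either direction. Compound 4 is therefore estimated at 75000 nM, with a range from 35000 nM to 160000 nM.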

Compound 4, half-maximal cytotoxic concentration: 75000 nM
Compound 4: the middle estimate sits on the measured number at the digits printed, and the stated range covers the measured number.
By their numbers in this assay, from the lowest: compounds 2, 3, 1 and 4 (each within the scatter of the next).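

In this assay, putting 4-methylphenyl in place of 3,4-dichlorophenyl on a sulfonyl sulfur gives a 1.1-fold higher number from compound 1 to compound 4 (0.02 log units; within the scatter), and this is a larger exchange than the earlier step on this ring, which replaced only one substituent. The entering group holds carbon only, so for this pair, a number in this range does not depend on chlorine being present on the ring attached to the sulfonyl sulfur. Nothing available here explains why the step stays within the scatter.

On these data alone, both groups in this step are six-membered aromatic rings of carbon only, so it remains open whether the number would hold with a carboxylic acid or an amine on that ring, or with a saturated ring or a longer alkyl chain on the sulfonyl sulfur. As far as these compounds go, it also remains open whether any exchange at this position can move the number beyond the scatter, and a basic amine or a carboxylic acid would be a clear first test of that.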